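This account rests on a few compounds, and the source may have more. Where it says the series, first, only, none or still open, it means among the compounds named here.

The compounds measured so far:
Compound 1, `O=C(Nc1cccc(-n2cc(-c3ccncc3)c(-c3ccc(Cl)c(O)c3)n2)c1)Nc1cccc(C(F)(F)F)c1`, gives > 32500 nM in a functional assay on NCI-H23 cells (Homo sapiens) for inhibition, read by sulforhodamine B assay, with a stated time of 48 h; a higher number here means that more compound is tolerated, a lower number that less compound is tolerated; this is a limit of the assay, not a number.
Compound 2, `COc1cc(-c2nn(-c3cccc(NC(=O)Nc4cc(C(F)(F)F)cc(C(F)(F)F)c4)c3)cc2-c2ccncc2)ccc1Cl`, gives 29600 nM in this assay.
Compound 3, `COc1cc(-c2nn(-c3cccc(NC(=O)Nc4cccc(C(F)(F)F)c4)c3)cc2-c2ccncc2)ccc1Cl`, gives > 50000 nM in this assay; this too is a limit, not a number.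

Among the measured compounds shown here, compound 2 therefore stands as the only compound of the three with a number in this assay; the two others sit at limits, the limit of > 32500 nM in this assay, at which 1 of the 3 values shown sits, and (the limit of > 50000 nM in this assay, at which 1 of the 3 values shown sits).

Compound 4, `O=C(Nc1cccc(-n2cc(-c3ccncc3)c(-c3ccc(Cl)c(O)c3)n2)c1)Nc1cc(C(F)(F)F)cc(C(F)(F)F)c1`, is not yet measured. It differs from compound 2 by hydrogen in place of methyl on an oxygen on an aromatic ring. The same change, in the other direction, is the step that the two limits leave unreadable from compound 1 to compound 3, which cannot be read because both ends are limits. The step of an at least 1.6-fold higher number from compound 2 to compound 3 (0.22 log units; that floor lies within the scatter) concerns a different position and only places compound 3 at a limit. Nothing measured therefore gives a readable size for the step from compound 2 to compound 4, and no step beyond the scatter is expected in this assay. Compound 4 is accordingly estimated at 30000 nM, with a range from 12000 nM to 70000 nM, which means an expected step of a 1.0-fold higher number from compound 2 to compound 4 (0.01 log units; within the scatter).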

Compound 4, concentration lethal to 50% of the cells: 18200 nM
Compound 4: middle estimate off by 1.6-fold (0.22 log units), on the high side; low and high end bracket the measured number.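

In this assay, the change from 4-chloro-3-methoxyphenyl to 4-chloro-3-hydroxyphenyl now has a readable size, a 1.6-fold lower number from compound 2 to compound 4 (0.21 log units; within the scatter), which the earlier pair with this change could not give. Adding trifluoromethyl on an aromatic carbon of the hydroxy compound gives an at least 1.7-fold lower number from compound 1 to compound 4 (0.25 log units; that floor lies within the scatter), and this is a floor only. That change can now be followed on two cores, but only as floors: the same change on two cores in this assay, an at least 1.6-fold higher number (0.22 log units; that floor lies within the scatter) from compound 2 to compound 3 and an at least 1.7-fold higher number (0.25 log units; that floor lies within the scatter) from compound 4 to compound 1; the limit leaves it open whether they differ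

From the compounds shown here alone, the step between compound 1 and compound 3 still cannot be read, as both ends are limits of the assay, so it remains open whether methoxy to hydroxy gives a similar step on that core. Also open, going by these compounds, is what an amine in place of the hydroxy, or a longer chain such as ethyl or propyl on the oxygen, would give in this assay.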